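Swapping the pendant aryl for a pyridine at the methine

This account rests on a few compounds, and the source may have more. Where it says the series, first, only, none or still open, it means among the compounds named here.

Measured compounds:
compound 1 `CCCCC(c1ccccc1)n1ccc2cc(/C(C)=C/C(=O)Nc3ccccc3OCCCC(=O)O)ccc21`: 9.8 nM
compound 2 `COc1ccc(C(c2ccccc2)n2ccc3cc(/C(C)=C/C(=O)Nc4ccccc4OCCCC(=O)O)ccc32)cc1`: 8.8 nM
compound 3 `C/C(=C\C(=O)Nc1ccccc1OCCCC(=O)O)c1ccc2c(ccn2C(c2ccccc2)c2ccc(C(F)(F)F)cc2)c1`: 8.1 nM

In an assay on Prostate gland for inhibition of steroid 5-alpha-reductase (Rattus norvegicus) (a higher number here means a weaker inhibitor, a lower number a stronger inhibitor), compound 3 gives the lowest of the three numbers, though its neighbours sit close: a 1.1-fold lower number from compound 2 to compound 3 (0.04 log units; within the scatter) and a 1.2-fold lower number from compound 1 to compound 3 (0.08 log units; within the scatter) are both small steps. The three compounds share a core and differ only in the group on a saturated chain carbon bound to an aromatic carbon and an aromatic nitrogen, and the numbers barely move across this series: a 1.1-fold lower number from compound 1 to compound 2 (0.05 log units; within the scatter) is as unremarkable as the others.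

Compound 4 `C/C(=C\C(=O)Nc1ccccc1OCCCC(=O)O)c1ccc2c(ccn2C(c2ccccc2)c2ccncc2)c1` has not yet been measured. It differs from compound 3 in one place: pyridin-4-yl in place of 4-(trifluoromethyl)phenyl on a saturated chain carbon bound to an aromatic carbon and an aromatic nitrogen. The three measured steps all bear on the same position and none of them rose above the scatter, which suggests that this position tolerates very different groups with little consequence in this assay. Going by the values given here, no measured step tests a ring with a hetero atom there, so some added uncertainty is warranted, but nothing in the data points to a large shift in either direction.

Compound 4 is therefore expected to give about 12 nM in this assay, somewhere between 5 nM and 35 nM. The expected step, a 1.5-fold higher number from compound 3 to compound 4 (0.17 log units; within the scatter), is estimated to stay within the scatter.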

Compound 4, half-maximal inhibitory concentration: 26 nM
Beside the measured number, compound 4's estimate is 2.2-fold (0.34 log units) below it; low and high end bracket the measured number.
By their numbers in this assay, from the lowest: compounds 3, 2 and 1 (each within the scatter of the next); then compound 4.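

In this assay, going by these compounds alone, pyridin-4-yl is the first group at this position to move the number beyond the scatter: the change gives a 3.2-fold higher number from compound 3 to compound 4 (0.51 log units; beyond the scatter) and a 3.0-fold higher number from compound 2 to compound 4 (0.47 log units; beyond the scatter) and also a 2.7-fold higher number from compound 1 to compound 4 (0.42 log units; beyond the scatter). Butyl, 4-methoxyphenyl and 4-(trifluoromethyl)phenyl had stayed within the scatter of one another, so the tolerance seen earlier holds for those three groups and does not extend to every group on this saturated chain carbon; the one ring with a hetero atom, and the only entering group with a hydrogen-bond acceptor counted on it, is the one that stands apart. Nothing among the data shown speaks to what lies behind this step.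

The compounds shown leave open whether the step belongs to the ring nitrogen itself: pyridin-4-yl differs from 4-methoxyphenyl and 4-(trifluoromethyl)phenyl both in that nitrogen and in having no substituent on the ring, and an unsubstituted phenyl would separate the two. They also leave open whether pyridin-3-yl or pyridin-2-yl, which place the nitrogen differently in the ring, would give a step of the same size.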